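The source may hold more compounds than are shown below. What is called first, only, known or untested is meant among the compounds shown, and "the series" means these compounds.

Measured in an ADME assay on HEK293 cells (Homo sapiens) for cytotoxicity, read by resazurin assay, with a stated time of 72 h; a lower number here means that less compound is tolerated, a higher number that more compound is tolerated:
Compound 1 `CCc1cccc(CNC(=O)c2nc3cccc(COCc4ccc(C(=O)O)cc4)c3c(=O)[nH]2)c1`: > 40000 nM, a limit
Compound 2 `CCc1cccc(CNC(=O)c2nc3ccc(OC)c(COCc4ccc(C(=O)O)cc4)c3c(=O)[nH]2)c1`: > 20000 nM, a limit

Compound 1 stands at > 40000 nM, which is a limit and not a number. Compound 3 `CCc1cccc(CNC(=O)c2nc3cccc(COCc4cccc(C(=O)O)c4)c3c(=O)[nH]2)c1` has the same atoms as compound 1, joined differently: 3-carboxyphenyl in place of 4-carboxyphenyl on a saturated chain carbon bound to an oxygen on a saturated carbon. Among the measured compounds shown here, the only measured step, a step that the two limits leave unreadable from compound 1 to compound 2, concerns a different change and gives no size to carry over. Compound 2 stands at > 20000 nM, also a limit. With compound 1 at > 40000 nM, no step beyond the scatter is expected in this assay. The expected step is a number no higher from compound 1 to compound 3 (the limit leaves the size open). Compound 3 is expected at 40000 nM, with an estimated range from 20000 nM to 80000 nM.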

Compound 3, half-maximal cytotoxic concentration: > 20000 nM
Compound 3: a limit, no number; the forecaster's own chance of this, stated with the estimate: 85%; the middle value lies beyond the limit too.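

Among the compounds shown here, compound 1 and compound 3 both stand only as limits in this assay, and no step between them can be read. The compounds shown leave open each compound's actual half-maximal cytotoxic concentration, and whether 3-carboxyphenyl in place of 4-carboxyphenyl changes it at all.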